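A few compounds are considered here, and "the series" means these few. Any claim that something is new, unique, unknown or untested is made for them only; others in the source may bear on it.

Measured so far in a functional assay on Jurkat cells (Homo sapiens) for antiproliferative activity, read by MTT assay, with a stated time of 72 h; a lower number here means a stronger inhibitor, a higher number a weaker inhibitor:
- compound 1 `O=C1C[C@@H]2O[C@@H](Cc3ccccc3)[C@@H](O)[C@@H]2O1`: 120 nM
- compound 2 `O=C1C[C@H]2O[C@H](Cc3ccccc3)[C@H](OCc3ccccc3)[C@H]2O1`: 1010 nM

Compound 2, at 1010 nM, holds the higher of the two numbers and so is the weaker inhibitor of the pair. Going by the values given here, its only neighbour is compound 1, at 120 nM, and the gap between them lies beyond the usual scatter.

The next compound is compound 3 `O=C1C[C@H]2O[C@H](Cc3ccccc3)[C@H](O)[C@H]2O1`, which is derived from compound 2 by one change: hydrogen in place of benzyl on an oxygen on a saturated carbon. This places hydrogen in place of benzyl on an oxygen on a saturated carbon, which reads as benzyloxy to hydroxy.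

Among the compounds with values here, no measured step isolates this change, so the expectation rests on two values alone and stays wide. Compound 1, the measured compound with a free hydroxy, stands at 120 nM, and this points towards a lower number in this assay. The expected change, beyond the scatter and towards a stronger inhibitor, is a 4.0-fold lower number from compound 2 to compound 3 (0.61 log units; beyond the scatter).

For compound 3 the estimated value is 250 nM, with an expected range of 50 nM to 1200 nM.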

Compound 3, half-maximal inhibitory concentration: 2520 nM
For compound 3 the middle estimate is 10-fold (1.00 log units) below the measured one; the measured number lies above the stated range.
By their numbers in this assay, from the lowest: compound 1; then compound 2; then compound 3.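

In this assay, hydrogen in place of benzyl on the oxygen on a saturated carbon does not give a stronger inhibitor in this configuration: a 2.5-fold higher number from compound 2 to compound 3 (0.40 log units; beyond the scatter). A free hydroxy at this position therefore does not by itself bring a low number, and benzyloxy to hydroxy is a modest weakening here. Configuration gives the large step, a 21-fold higher number from compound 1 to compound 3 (1.32 log units; beyond the scatter), and the whole of that gap goes with the drawn stereochemistry, because of one fact: the fact that compounds 1 and 3 differ only in the configuration as drawn.

The benzyloxy to hydroxy step is read only in the configuration of compound 3, so its direction and size in the configuration of compound 1 stay open, as does which of the stereocentres carries the gap, since only the full mirror-image pair is shown. Also open, going by these compounds, is how the number would move with a methyl or an acetyl on that oxygen, or with an amine in place of the hydroxy.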